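The source may hold more compounds than are shown below. What is called first, only, known or untested is meant among the compounds shown, and "the series" means these compounds.

Measured in a functional assay on HeLa cells (Homo sapiens) for inhibition, read by sulforhodamine B assay; on this read-out lower numbers stand for stronger inhibition and higher numbers for weaker inhibition:
- compound 1 `COc1ccccc1NC1=CC(=O)c2nc3n(c2C1=O)[C@H]1OC[C@@H](O)[C@H]1OC3`: 2950 nM
- compound 2 `Cc1ccc(NC2=CC(=O)c3nc4n(c3C2=O)[C@H]2OC[C@@H](O)[C@H]2OC4)cc1C`: 2690 nM
- compound 3 `CCCN(CCC)C1=CC(=O)c2nc3n(c2C1=O)[C@H]1OC[C@@H](O)[C@H]1OC3`: > 16000 nM (a limit, not a number)

Compound 3 has no number on this read-out, only a limit: the limit of > 16000 nM in this assay, at which 1 of the 3 values shown sits.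

Compound 4 `O=C1C=C(Nc2ccc(I)cc2)C(=O)c2c1nc1n2[C@H]2OC[C@@H](O)[C@H]2OC1` has (4-iodophenyl)amino in place of dipropylamino on a double-bonded ring carbon. Two measured steps make the reverse kind of change: an at least 5.4-fold higher number from compound 1 to compound 3 (0.73 log units; beyond the scatter) and an at least 5.9-fold higher number from compound 2 to compound 3 (0.77 log units; beyond the scatter). The two arylamino compounds differ only within the scatter: a 1.1-fold lower number from compound 1 to compound 2 (0.04 log units; within the scatter). A step of similar size toward lower numbers in this assay is therefore expected, again bounded by the limit of compound 3. The expected step is an at least 5.7-fold lower number from compound 3 to compound 4 (0.75 log units; beyond the scatter). For compound 4 the estimated value is 2800 nM, with an expected range from 1000 nM to 8000 nM.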

Compound 4, half-maximal inhibitory concentration: 4070 nM
Compound 4: middle estimate off by 1.5-fold (0.16 log units), on the low side; measured number inside the range.
By their numbers in this assay, from the lowest: compounds 2, 1 and 4 (each within the scatter of the next). At a limit, above all of these: compound 3.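

Placing (4-iodophenyl)amino in place of dipropylamino on the double-bonded ring carbon gives an at least 3.9-fold lower number from compound 3 to compound 4 (0.59 log units; beyond the scatter) in this assay. The new aryl group stays level with the other two: a 1.5-fold higher number from compound 2 to compound 4 (0.18 log units; within the scatter), and a 1.4-fold higher number from compound 1 to compound 4 (0.14 log units; within the scatter). Across compound 1, compound 2 and compound 4, an iodine on the aryl ring therefore fits the same picture as the methoxy and dimethyl patterns, with none of the three standing apart.

As far as these compounds go, compound 3 carries only a limit, so the full size of its step stays open: the limit of > 16000 nM in this assay, at which 1 of the 4 values shown sits. Whether the aryl ring itself is needed also stays open, as a benzylamine or a morpholine at this carbon would test.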